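The compounds below may be only part of what the source reports. "The series", "measured", "known", "first", "only" and "open" are said of these compounds alone.

Of the compounds shown here, three from one series have so far been measured in a functional assay on MCF7 cells (Homo sapiens) for antiproliferative activity, read by MTT assay, with a stated time of 72 h; on this read-out lower numbers stand for stronger inhibition and higher numbers for weaker inhibition. Compound 1, `CC1=CC[C@H]2[C@H](CC[C@]2(C)O)C(C)(C)[C@@H]1CC[C@H]1[C@]2(C)CC[C@H](OC(=O)c3ccc(C)cc3)C(C)(C)O[C@H]2CC[C@@]1(C)O`, gives in this assay > 50000 nM, which is a limit of the assay and not a number. Compound 2, `CC1=CC[C@H]2[C@@H]1CC=C(C)[C@@H](CC[C@H]1[C@]3(C)CC[C@H](OC(=O)CCC(=O)O)C(C)(C)O[C@H]3CC[C@@]1(C)O)C2(C)C`, likewise gives only a limit in this assay, > 50000 nM. Compound 3, `CC1=CC[C@H]2[C@H](CC[C@]2(C)O)C(C)(C)[C@@H]1CC[C@H]1[C@]2(C)CC/C(=N/O)C(C)(C)O[C@H]2CC[C@@]1(C)O`, gives in this assay 46800 nM. Among the compounds with values here, compound 1 therefore stands at the limit of > 50000 nM in this assay, at which 2 of the 3 values shown sit, and since no two measured compounds differ in a single place, no step between measured compounds can be sized; all three values lie at the weak end of the read-out.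

Compound 4, `CC1=CC[C@H]2[C@H](CC[C@]2(C)O)C(C)(C)[C@@H]1CC[C@H]1[C@]2(C)CC[C@H](OC(=O)c3ccc([N+](=O)[O-])o3)C(C)(C)O[C@H]2CC[C@@]1(C)O`, has not yet been measured. It differs from compound 1 in one place: 5-nitrofuran-2-yl in place of 4-methylphenyl on a carbonyl carbon. Nothing measured here crosses that change, and the three compounds already in hand give no sign of any step beyond the usual scatter. The step of an at least 1.6-fold lower number from compound 1 to compound 4 (0.22 log units; that floor lies within the scatter) is accordingly expected to be small, with a real chance that the assay once more reports only a limit rather than a number. Compound 4 is thus estimated to give 30000 nM, with the value expected to fall somewhere between 8000 nM and 100000 nM.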

Compound 4, half-maximal inhibitory concentration: 21300 nM
Beside the measured number, compound 4's estimate is 1.4-fold (0.15 log units) above it, within the range that was stated.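

Within the data shown here, the carbonyl carbon whose other neighbours are oxygen next to a carbonyl group proves to be a place where this assay responds: 5-nitrofuran-2-yl in place of 4-methylphenyl gives an at least 2.3-fold lower number from compound 1 to compound 4 (0.37 log units; beyond the scatter), the first step that can be sized, and it lies beyond the scatter. From the compounds shown here alone, compound 1 gives > 50000 nM, which is a limit of the assay and not a number, so the true size of this step stays unknown: the limit of > 50000 nM in this assay, at which 2 of the 4 values shown sit.

Compound 4 nevertheless gives 21300 nM, a real number that still lies at the weak end of the read-out, so the change brings the compound within measuring range without carrying it far along.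

Going by these compounds, whether the step belongs to the nitro group or to the furan ring remains open, and a plain furan-2-yl or a 4-nitrophenyl on the same carbonyl carbon would separate the two. On these data alone, how an aminophenyl group or a longer alkyl chain in this place would read in this assay also remains open.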